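The source may hold more compounds than are shown below. What is called first, only, known or untested is meant among the compounds shown, and "the series" means these compounds.

Compound 2 `O=c1ncccn1SCCc1ccc(Nc2ncc(Cc3c(F)cccc3F)o2)cc1` was examined in an ADME assay on MT2 cells (Homo sapiens) for cytotoxicity, read by MTT assay; on this read-out higher numbers stand for lower toxicity in this test and lower numbers for higher toxicity in this test. In this assay compound 2 gives only a limit, > 100000 nM, and no number. Compound 1 `Clc1cccc(Cl)c1Cc1nnc(Nc2ccc(COCc3ccsc3)cc2)o1`, measured in this assay as well, also gives only a limit, > 100000 nM. Among the measured compounds shown here, both results sit at the limit of > 100000 nM in this assay, at which 2 of the 2 values shown sit, so compound 2 stands where the one other measured compound stands, and no step between measured compounds can be drawn from these two results.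

Compound 3 `COCc1ccc(Nc2ncc(Cc3c(F)cccc3F)o2)cc1` differs from compound 2 in a single place: a group of 2 heavy atoms (1 carbon, 1 oxygen; no ring) in place of a group of 9 heavy atoms (5 carbon, 2 nitrogen, 1 oxygen, 1 sulfur; one six-membered aromatic ring with 2 hetero atoms), on a saturated chain carbon bound to an aromatic carbon. For the measured compounds named here, with no measured step to lean on, the expected step in this assay is a number no higher from compound 2 to compound 3 (the limit leaves the size open), that is, none beyond the usual scatter. Compound 3 is therefore expected to give 100000 nM in this assay, with a range from 50000 nM to 200000 nM, and most probably again only a limit rather than a number.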

Compound 3, half-maximal cytotoxic concentration: 32000 nM
For compound 3 the middle estimate is 3.1-fold (0.49 log units) above the measured one; measured number below the stated range.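

In this assay, methoxy in place of the larger group on this saturated chain carbon bound to an aromatic carbon gives an at least 3.1-fold lower number from compound 2 to compound 3 (0.49 log units; beyond the scatter), and compound 3 at 32000 nM is the first compound shown with a number rather than a limit. Among the compounds shown here, this shows that the group at this place can change the read-out, which the earlier compounds could not show, as they gave no readable step: the limit of > 100000 nM in this assay, at which 2 of the 3 values shown sit. The step has only a smallest size, since the result for compound 2 is a limit and not a number.

As far as these compounds go, it remains open whether another small group at this place, such as a hydroxyl or an ethoxy, would give a similar number. From the compounds shown here alone, it also remains open whether methoxy at the corresponding place on the core of compound 1 would lower its number too.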